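Swapping halogens on a shared amide core

The source may hold more compounds than are shown below. What is called first, only, known or untested is meant among the compounds shown, and "the series" means these compounds.

Three closely related compounds share one core and differ only in a single halogen. Compound 1 `O=C(Nc1ccc(Br)cc1F)c1cc(I)ccc1O`, compound 2 `O=C(Nc1ccc(Cl)cc1F)c1cc(I)ccc1O` and compound 3 `O=C(Nc1ccc(I)cc1F)c1cc(I)ccc1O` were each tested in an ADME assay on RAW264.7 cells (Mus musculus) for cytotoxicity, read by MTT assay, with a stated time of 24 h; on this read-out lower numbers stand for higher toxicity in this test and higher numbers for lower toxicity in this test. In this assay compound 1 gives 8400 nM, compound 2 gives 8500 nM and compound 3 gives 6000 nM. The change bromo in place of iodo on an aromatic carbon made a step of a 1.4-fold higher number from compound 3 to compound 1 (0.15 log units; within the scatter). Compound 2 and compound 3 differ by chloro in place of iodo on an aromatic carbon.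

Compound 4 `O=C(Nc1ccc(Cl)cc1F)c1cc(Br)ccc1O` has not yet been measured. It arises from compound 2 by bromo in place of iodo on an aromatic carbon. For the measured compounds named here, this is the same kind of change as the one from compound 3 to compound 1, but the place differs: there it is meta to a fluoro group (1 heavy atom) and para to a large group, here it is meta to a large group and para to a hydroxy group (1 heavy atom). Because the earlier step of a 1.4-fold higher number from compound 3 to compound 1 (0.15 log units; within the scatter) stayed within the scatter, a similarly small step of a 1.2-fold higher number from compound 2 to compound 4 (0.07 log units; within the scatter) is expected, resting on that one prior example. Compound 4 is therefore estimated at 10000 nM, likely between 5000 nM and 20000 nM.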

Compound 4, half-maximal cytotoxic concentration: 9200 nM
Beside the measured number, compound 4's estimate is 1.1-fold (0.04 log units) above it; low and high end bracket the measured number.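

In this assay, putting bromo in place of iodo on the core of compound 2 gives a 1.1-fold higher number from compound 2 to compound 4 (0.03 log units; within the scatter). Set beside the same swap at the other halogen place, the two steps agree: the same change on two cores in this assay, a 1.4-fold higher number (0.15 log units; within the scatter) from compound 3 to compound 1 and a 1.1-fold higher number (0.03 log units; within the scatter) from compound 2 to compound 4, 1.3-fold (0.11 log units) apart, within the scatter of two such steps. This shows that in these two cases the swap made no difference that can be told from the scatter, whichever of the two places it occupied, but two such small steps do not show that it would stay this small on other cores, and they cannot reveal a real but very small effect.

All the compounds shown carry only halogens at the two places that vary, and they keep the hydroxy group and the amide of the shared core. As far as these compounds go, what remains open is how a group of another kind, such as an amine, a carboxylic acid or a longer alkyl chain, would read in this assay at either of those places.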